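A Benzyl Swap on the Shared Core

The source may report more compounds than this note shows. Statements on the series, on what has been measured and on what is new or still open speak of the compounds shown alone.

Compound 1 `O=C1C=C(NCc2ccccc2)C(=O)c2c1nc1n2[C@H]2OC[C@@H](O)[C@H]2OC1`: 2670 nM
Compound 2 `COc1ccccc1NC1=CC(=O)c2c(nc3n2[C@H]2OC[C@@H](O)[C@H]2OC3)C1=O`: 1670 nM
Compound 3 `O=C1C(N2CCCC2)=CC(=O)c2c1nc1n2[C@H]2OC[C@@H](O)[C@H]2OC1`: > 16000 nM

All three compounds were tested in a functional assay on MGC-803 cells (Homo sapiens) for inhibition, read by sulforhodamine B assay (on this read-out lower numbers stand for stronger inhibition and higher numbers for weaker inhibition), and share one core. Compound 1 (2670 nM) lies within the scatter of compound 2 (1670 nM), so the two cannot be ranked. The value of compound 3 (> 16000 nM) is a limit of the assay and not a number.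

The next compound, compound 4 `CCOc1ccc(NC2=CC(=O)c3nc4n(c3C2=O)[C@H]2OC[C@@H](O)[C@H]2OC4)cc1`, has not yet been measured. Compared with compound 1, it has 4-ethoxyphenyl in place of benzyl on an amine nitrogen. For the measured compounds named here, only one measured step bears on this site, and only indirectly. Pyrrolidin-1-yl in place of (2-methoxyphenyl)amino on a double-bonded ring carbon gave a large change (an at least 9.5-fold higher number from compound 2 to compound 3 (0.98 log units; beyond the scatter)). Compound 4 does not make that kind of change: like compound 2 (1670 nM), it keeps an aromatic ring on an amine nitrogen. Going by these compounds, no step beyond the scatter is therefore expected in this assay and the direction stays open. The estimated step is small (a 1.3-fold lower number from compound 1 to compound 4 (0.13 log units; within the scatter)). For compound 4 the expected value is 2000 nM with an estimated range from 700 nM to 6000 nM as its likely span.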

Compound 4, half-maximal inhibitory concentration: 1110 nM
Beside the measured number, compound 4's estimate is 1.8-fold (0.26 log units) above it; the measured number falls inside the stated range.
By their numbers in this assay, from the lowest: compounds 4, 2 and 1 (each within the scatter of the next, the first and the last beyond it). At a limit, above all of these: compound 3.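

Read directly on the amine nitrogen, 4-ethoxyphenyl in place of benzyl gives a 2.4-fold lower number from compound 1 to compound 4 (0.38 log units; beyond the scatter) in this assay, the first change at this site among the aromatic groups that lies beyond the scatter, though it is only modest. Compound 2 at 1670 nM lies within the scatter of each of the other two, so only the two ends of this short series can be told apart, and no general rule for aromatic groups at this site follows from them. Nothing measured here offers a reason for this step.

Going by these compounds, whether the step comes from the ethoxy group or from removing the benzyl methylene stays open, and an unsubstituted phenyl, a 4-methoxyphenyl or a 4-hydroxyphenyl group would be needed to separate the two. On these data alone, for compound 3 the entry > 16000 nM is a limit of the assay and not a number, so the true size of the loss with pyrrolidin-1-yl remains unknown, as does the outcome with an open-chain amine such as diethylamino.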